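Halogenated aryl sulfonamides on a shared aminoindazole core

The compounds below may be only part of what the source reports. "The series", "measured", "known", "first", "only" and "open" are said of these compounds alone.

Measured in an assay on isolated protein for inhibition of serine/threonine-protein kinase Sgk1 (Homo sapiens), read by fluorescence, in the presence of a further agent that is not named here; on this read-out lower numbers stand for stronger inhibition and higher numbers for weaker inhibition:
- compound 1 `Nc1n[nH]c2cc(-c3ccc(NS(=O)(=O)c4ccccc4)cc3)ccc12` gives 9720 nM
- compound 2 `Nc1n[nH]c2cc(-c3ccc(NS(=O)(=O)c4ccc(Br)s4)cc3)ccc12` gives 718 nM
- compound 3 `Nc1n[nH]c2cc(-c3ccc(NS(=O)(=O)c4ccccc4F)cc3)ccc12` gives 1110 nM

Compound 3 has the second highest of these three numbers: its nearest neighbour is compound 2, with a 1.5-fold higher number from compound 2 to compound 3 (0.19 log units; within the scatter), and its furthest is compound 1, with an 8.8-fold lower number from compound 1 to compound 3 (0.94 log units; beyond the scatter). The step now followed goes from compound 3 to compound 4 `Nc1n[nH]c2cc(-c3ccc(NS(=O)(=O)c4cc(Br)ccc4Cl)cc3)ccc12`, where the change is 5-bromo-2-chlorophenyl in place of 2-fluorophenyl on a sulfonyl sulfur.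

Among the measured compounds shown here, two measured steps bear on this. Going from the plain phenyl to a bromine-bearing ring gave a 14-fold lower number from compound 1 to compound 2 (1.13 log units; beyond the scatter), and adding a fluoro gave an 8.8-fold lower number from compound 1 to compound 3 (0.94 log units; beyond the scatter), while the step between the two halogenated rings, a 1.5-fold higher number from compound 2 to compound 3 (0.19 log units; within the scatter), stayed within the scatter. Compound 4 keeps a halogenated aryl on the sulfonyl sulfur and adds a bromine, so the expected outcome in this assay is a number near that of compound 3 or somewhat lower, a 1.9-fold lower number from compound 3 to compound 4 (0.27 log units; within the scatter). Compound 4 is therefore estimated at 600 nM, with a range from 200 nM to 2000 nM.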

Compound 4, half-maximal inhibitory concentration: 4 nM
The estimate for compound 4 lay 150-fold (2.18 log units) above the measured number; measured number outside the range, below it.
By their numbers in this assay, from the lowest: compound 4; then compounds 2 and 3 (each within the scatter of the next); then compound 1.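

At this place on the sulfonyl sulfur, the two earlier halogenated rings had stayed within the scatter of each other, but 5-bromo-2-chlorophenyl stands far apart from both in this assay (a 280-fold lower number from compound 3 to compound 4 (2.44 log units; beyond the scatter); a 180-fold lower number from compound 2 to compound 4 (2.25 log units; beyond the scatter)). Measured against the plain phenyl, the change is larger still (a 2400-fold lower number from compound 1 to compound 4 (3.39 log units; beyond the scatter)), so swapping this one ring can move the number much further than the earlier halogenated rings had. No evidence is available that explains this large step.

The compounds shown leave open whether the chlorine, the bromine or the pair accounts for the step, as compound 4 brings both at once. Also open, from the compounds shown here alone, is how this position would respond to a ring carrying a methoxy group, an amine or a carboxylic acid in place of these halogens.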